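This account rests on a few compounds, and the source may have more. Where it says the series, first, only, none or still open, it means among the compounds named here.

Compound 1, `COc1ccccc1C(=O)c1ccc(OS(N)(=O)=O)cc1`, was examined in an assay on isolated protein for inhibition of Steryl-sulfatase (Homo sapiens) (on this read-out lower numbers stand for stronger inhibition and higher numbers for weaker inhibition), where compound 1 gives 4800 nM. Its counterpart compound 2, `NS(=O)(=O)Oc1ccc(C(=O)c2ccccc2O)cc1`, differs by hydrogen in place of methyl on an oxygen on an aromatic ring and in this assay compound 2 gives 4600 nM; the step of a 1.0-fold lower number from compound 1 to compound 2 (0.02 log units; within the scatter) is within the scatter. Compound 3, `COc1cccc(C(=O)c2cccc(OS(N)(=O)=O)c2)c1`, is built from the same atoms joined differently, and the difference between the two cores is not broken down here; in this assay compound 3 gives 7100 nM, the highest of the three numbers, though its distances to compound 1 and compound 2 stay within the scatter. Compound 4, `NS(=O)(=O)Oc1cccc(C(=O)c2cccc(O)c2)c1`, carries the same change on the core of compound 3, namely (hydrogen in place of methyl on an oxygen on an aromatic ring). Because the earlier step of a 1.0-fold lower number from compound 1 to compound 2 (0.02 log units; within the scatter) was within the scatter, the step of a 1.0-fold lower number from compound 3 to compound 4 (0.01 log units; within the scatter) is expected to be similarly small. Compound 4 is therefore estimated at 7000 nM, expected between 3500 nM and 14000 nM.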

Compound 4, half-maximal inhibitory concentration: 6900 nM
Compound 4: the middle estimate sits 1.0-fold (0.01 log units) above what was measured, within the range that was stated.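

In this assay, the change from methoxy to hydroxy gives a 1.0-fold lower number from compound 3 to compound 4 (0.01 log units; within the scatter). Set beside the earlier step, the same change behaves alike on both cores, with no difference that can be told apart: the same change on two cores in this assay, a 1.0-fold lower number (0.02 log units; within the scatter) from compound 1 to compound 2 and a 1.0-fold lower number (0.01 log units; within the scatter) from compound 3 to compound 4, 1.0-fold (0.01 log units) apart, within the scatter of two such steps. This shows that, on these two cores, hydrogen in place of methyl on this oxygen leaves the number within the scatter, but two pairs do not show that this would hold on any further core, and they give no reason for it.

The compounds shown leave open whether a longer chain on that oxygen would behave in the same way. They also leave open what an amine or a carboxylic acid in place of the methoxy would do.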